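Removing a fluorine from compound 3: what to expect

This account rests on a few compounds, and the source may have more. Where it says the series, first, only, none or still open, it means among the compounds named here.

Of the compounds shown here, three have been measured in an assay for inhibition of histone-lysine N-methyltransferase, H3 lysine-79 specific (Homo sapiens), read by scintillation counting, with stated times of 15 min and 60 min, tested at 50 uM, in the presence of a further agent that is not named here; on this read-out higher numbers stand for a stronger effect at the one concentration tested and lower numbers for a weaker effect. Compound 1 `C(=C/c1nn2c(C3CCCCC3)nnc2s1)\c1ccco1` gives 68%. Compound 2 `Cc1occc1-c1nnc2sc(Cc3ccccc3)nn12` gives 13%. Compound 3 `Fc1cccc(-c2nnc3sc(/C=C/c4ccco4)nn23)c1` gives 22%, which places it second highest of the three numbers; its nearest neighbour is compound 2, a gap that lies within the scatter, and its furthest is compound 1, a gap well beyond the scatter.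

The compound now in question, compound 4 `C(=C/c1nn2c(-c3ccccc3)nnc2s1)\c1ccco1`, differs from compound 3 in one place: hydrogen in place of fluoro on an aromatic carbon.

Within the data shown here, only one measured step concerns a single change: a number 46 percentage points lower from compound 1 to compound 3 (beyond the scatter). That step swapped a whole ring for another, a far larger change than losing one fluorine, so it shows that this position can matter but does not show what a fluorine alone contributes. Among the measured compounds shown here, no measured pair differs by just a fluorine, so there is no direct guide. Given that, compound 4 is expected to sit close to compound 3, with a step of a number 2 percentage points higher from compound 3 to compound 4 (within the scatter), which is not beyond the scatter. The estimate for compound 4 in this assay is therefore 24%, with a range from 8% to 45%.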

Compound 4, a percentage reported as inhibition, at one concentration (the size of the read-out at that concentration, not a potency): 79%
The estimate for compound 4 lay 55 percentage points below the measured number, and the stated range ends below it.
By their numbers in this assay, from the lowest: compounds 2 and 3 (each within the scatter of the next); then compound 1; then compound 4.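

In this assay, among these compounds, taking away the single fluorine gives a number 57 percentage points higher from compound 3 to compound 4 (beyond the scatter) and so shows that one atom at this place, meta to a large group on the six-membered aromatic ring, can decide much of the read-out at the one concentration tested. Replacing cyclohexyl with plain phenyl gives a number 11 percentage points higher from compound 1 to compound 4 (beyond the scatter) and is a modest step in the opposite direction from the earlier fall to the 3-fluorophenyl compound. The aromatic ring on its own therefore does not account for that fall, which appears only when the fluorine is present, and the earlier ring swap had mixed these two changes together.

The compounds shown leave open whether the sensitivity is special to fluorine or extends to other groups at this place, such as chlorine, a methoxy group or an amine, and whether the same fluorine elsewhere on the ring would have a similar effect. Nothing available here gives a measured explanation for why this single atom changes the read-out so strongly.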